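Oxazolylamino for propylamino in a cytotoxicity-limited series

The compounds below may be only part of what the source reports. "The series", "measured", "known", "first", "only" and "open" are said of these compounds alone.

The three measured compounds share the core of compound 3 `CCCNc1nc(C)c(-c2nc3ccccc3s2)c(N[C@@H]2C[C@H](CO)[C@@H](O)[C@H]2O)n1`. In an ADME assay on cells (Homo sapiens) for cytotoxicity, read by polymerase chain reaction, with a stated time of 3 days (a lower number here means that less compound is tolerated, a higher number that more compound is tolerated), compound 3 reaches only a limit, > 25000 nM. Compound 1 `CCOc1ccc2nc(-c3c(Cl)nc(N)nc3N[C@@H]3C[C@H](CO)[C@@H](O)[C@H]3O)sc2c1` likewise gives only a limit in this assay, > 25000 nM. Compound 2 `CN(C)c1ccc2sc(-c3c(Cl)nc(N)nc3N[C@@H]3C[C@H](CO)[C@@H](O)[C@H]3O)nc2c1` gives a number in this assay, 25000 nM. Two of the three values therefore sit at the limit of > 25000 nM in this assay, at which 2 of the 3 values shown sit, and compound 3 stands among them, so no order between compound 3 and the other two can be read from these numbers. Among the measured compounds shown here, no pair of measured compounds differs in a single place, so no measured step is available.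

Compound 4 `Cc1nc(Nc2ncco2)nc(N[C@@H]2C[C@H](CO)[C@@H](O)[C@H]2O)c1-c1nc2ccccc2s1` is not yet measured. Against compound 3 the change is 1,3-oxazol-2-yl in place of propyl on a nitrogen on an aromatic ring. The expected step of a number no higher from compound 3 to compound 4 (the limit leaves the size open) is none beyond the scatter because compound 3 sits at the limit of > 25000 nM in this assay, at which 2 of the 3 values shown sit, and nothing else points away from it. For compound 4 the estimate in this assay is 25000 nM, in the range 10000 nM to 60000 nM, most likely reported again as a limit.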

Compound 4, half-maximal cytotoxic concentration: > 25000 nM
Compound 4: a limit, no number; the forecaster's own chance of this, stated with the estimate: 70%; the middle value lies on the limit itself.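

In this assay compound 4 gives > 25000 nM, a limit. Among the compounds shown here, compound 3 also gives only a limit, and no step between compound 3 and compound 4 can be read; the series gathers at one value: the limit of > 25000 nM in this assay, at which 3 of the 4 values shown sit. On these data alone, whether (1,3-oxazol-2-yl)amino for propylamino changes cytotoxicity at all remains open.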